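From phenyl to 4-fluorophenyl on compound 3

This account rests on a few compounds, and the source may have more. Where it says the series, first, only, none or still open, it means among the compounds named here.

In a functional assay on MCF7 cells (Homo sapiens) for antiproliferative activity, read by MTT assay, with a stated time of 72 h (on this read-out lower numbers stand for stronger inhibition and higher numbers for weaker inhibition), compound 3 `O=C(N/N=C/c1ccccc1)Nc1ccc(Oc2ccnc3[nH]ccc23)cc1` gives 1510 nM. Compound 1 `O=C(N/N=C/c1ccccc1)Nc1ccc(Oc2ccnc3[nH]ccc23)c(F)c1` gives 2380 nM. Hydrogen in place of fluoro on an aromatic carbon accounts for the difference between these two structures, and the result is a 1.6-fold lower number from compound 1 to compound 3 (0.20 log units; within the scatter). Compound 3 therefore shares the high end of the numbers with compound 1. Compound 2 `O=C(N/N=C/c1cccc(Br)c1)Nc1ccc(Oc2ccnc3[nH]ccc23)c(F)c1` lies far lower, at 49 nM.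

Compound 4 `O=C(N/N=C/c1ccc(F)cc1)Nc1ccc(Oc2ccnc3[nH]ccc23)cc1` carries fluoro in place of hydrogen on an aromatic carbon, turning phenyl into 4-fluorophenyl: fluoro in place of hydrogen on an aromatic carbon. Among the compounds with values here, two measured steps bear on this change. Bromo in place of hydrogen gives a 49-fold lower number from compound 1 to compound 2 (1.69 log units; beyond the scatter), the only measured substitution on this ring. That step is large, but it involves a different halogen and starts from compound 1. The second is a 1.6-fold lower number from compound 1 to compound 3 (0.20 log units; within the scatter), which shows a fluoro exchange elsewhere in the molecule staying within the scatter. No fluoro on this ring has been measured, so the evidence is indirect.

A moderate move toward lower numbers is expected, estimated as a 2.2-fold lower number from compound 3 to compound 4 (0.33 log units; beyond the scatter), well short of the bromo step. For compound 4 the expected value is 700 nM, with an estimated range of 170 nM to 2200 nM.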

Compound 4, half-maximal inhibitory concentration: 3720 nM
Compound 4: the middle estimate sits 5.3-fold (0.73 log units) below what was measured, outside the stated range (above it).
By their numbers in this assay, from the lowest: compound 2; then compounds 3, 1 and 4 (each within the scatter of the next, the first and the last beyond it).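

In this assay, within the data shown here, the step of a 2.5-fold higher number from compound 3 to compound 4 (0.39 log units; beyond the scatter) is the first direct reading of a halogen placed para to a large group on this phenyl, and it runs toward weaker inhibition, a modest change that lies beyond the scatter. Halogen on this phenyl therefore has no single direction across the compounds shown: the step of a 49-fold lower number from compound 1 to compound 2 (1.69 log units; beyond the scatter) runs the other way and is large, although that pair differs from this one in the halogen, in its place on the ring and in the starting compound. Among these compounds, nothing measured so far explains the opposite directions of these two steps.

Still open, from the compounds shown here alone, is whether the bromo step depends on where the bromo sits or on the halogen itself, and whether fluoro at this same place would give a similar step on the fluorinated core of compound 1. Going by these compounds, it is also open how the read-out responds at this position to groups other than halogens, such as an amine, a methoxy group or a carboxylic acid.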